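Solubility notes on a furanylmethylamine-linked quinoline series

The source may report more compounds than this note shows. Statements on the series, on what has been measured and on what is new or still open speak of the compounds shown alone.

Measured so far:
compound 1 `Cc1cc(C)cc(Cc2ccc3c(NCCCNCc4ccco4)ccnc3c2)c1` 4200 nM
compound 2 `COc1ccc(-c2ccc3c(NCCCNCc4ccco4)ccnc3c2)cc1` 32000 nM
compound 3 `CC(C)(C)c1ccc(-c2ccc3c(NCCCNCc4ccco4)ccnc3c2)cc1` 32000 nM

In a physicochemical assay for solubility, with a stated time of 18 h, at pH 7.4 (a lower number here means a less soluble compound, a higher number a more soluble compound), compound 3 stands level with compound 2 at the digits printed, the two together giving the highest numbers of the three; compound 1 sits furthest away, a 7.6-fold higher number from compound 1 to compound 3 (0.88 log units; beyond the scatter).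

Compound 4 `N#Cc1ccc(Cc2ccc3c(NCCCNCc4ccco4)ccnc3c2)cc1` is not yet measured in this assay. Its change from compound 3 is 4-cyanobenzyl in place of 4-(tert-butyl)phenyl on an aromatic carbon.

Going by the values given here, two measured steps bear on it. Both a 7.6-fold higher number from compound 1 to compound 2 (0.88 log units; beyond the scatter) and a 7.6-fold higher number from compound 1 to compound 3 (0.88 log units; beyond the scatter) replaced a benzyl group with a directly attached aryl group and raised the number by the same modest amount. The present change runs the other way, back from an aryl to a benzyl group. The step of no change at the digits printed from compound 2 to compound 3 (within the scatter) shows that swapping the group on the distal ring alone made no difference within the scatter, so the ring substituent is given little weight here.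

Compound 4 is therefore expected to drop in this assay, a 5.3-fold lower number from compound 3 to compound 4 (0.73 log units; beyond the scatter), toward the level of compound 1 at 4200 nM. The estimate for compound 4 is 6000 nM, with a range of 2000 nM to 18000 nM.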

Compound 4, solubility: 4200 nM
For compound 4 the middle estimate is 1.4-fold (0.15 log units) above the measured one, and the stated range covers the measured number.
By their numbers in this assay, from the lowest: compounds 1 and 4 (each within the scatter of the next); then compounds 2 and 3 (each within the scatter of the next).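

Going by these compounds alone, at this aromatic carbon, the two benzyl compounds now sit together and the two directly attached aryl compounds sit together in this assay, with no compound of the four going against that split. The new compound gives the same gap against either aryl compound (a 7.6-fold lower number from compound 3 to compound 4 (0.88 log units; beyond the scatter); a 7.6-fold lower number from compound 2 to compound 4 (0.88 log units; beyond the scatter)), so the earlier gap is no longer tied to the 3,5-dimethylbenzyl group alone. Within the benzyl pair, 4-cyanophenyl in place of 3,5-dimethylphenyl on the saturated chain carbon leaves the number unmoved (no change at the digits printed from compound 1 to compound 4 (within the scatter)), although a nitrile replaces two methyl groups.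

Still open, on these data alone, are the effect of an amine or a carboxylic acid on the outer ring, and of a longer chain in place of the benzyl carbon, as well as any comparison of one ring substituent with and without that carbon. Nothing measured here accounts for the split between benzyl and aryl compounds.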